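A few compounds are considered here, and "the series" means these few. Any claim that something is new, unique, unknown or untested is made for them only; others in the source may bear on it.

Compound 1 `NS(=O)(=O)c1cccc(-c2nnc(-c3ccc(F)cc3)o2)c1` and compound 2 `NS(=O)(=O)c1ccc(C(=O)NNC(=O)c2ccc(F)cc2)cc1` each carry a primary sulfonamide and a 4-fluorophenyl group on a different central core; the difference between the two cores is not broken down here. Compound 3 `NS(=O)(=O)c1cccc(-c2nnc(-c3ccc(Cl)cc3)o2)c1` is compound 1 with the change (chloro in place of fluoro on an aromatic carbon). In an assay on cells for inhibition of Amine oxidase [flavin-containing] A (Homo sapiens), read by fluorescence and spectrophotometry, using microsomes, with a stated time of 20 min (on this read-out higher numbers stand for weaker inhibition and lower numbers for stronger inhibition), compound 1 gives 34400 nM. In this assay compound 2 gives 39600 nM, which sits within the scatter of compound 1. In this assay compound 3 gives > 100000 nM, a limit of the assay rather than a number. The step of an at least 2.9-fold higher number from compound 1 to compound 3 (0.46 log units; beyond the scatter) is therefore a lower bound, because of the limit of > 100000 nM in this assay, at which 1 of the 3 values shown sits.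

Compound 4 `NS(=O)(=O)c1ccc(C(=O)NNC(=O)c2ccc(Cl)cc2)cc1` is compound 2 with the change (chloro in place of fluoro on an aromatic carbon), the same kind of change on the same place as in compound 3 but on the core of compound 2. Only one such step is shown, so the expectation rests on compound 1 and compound 3 alone: the step to compound 4 is expected to be a 2.5-fold higher number from compound 2 to compound 4 (0.40 log units; beyond the scatter), and compound 4 is expected to give about 100000 nM in this assay, between 40000 nM and 300000 nM, with a fair chance that only a limit is reported.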

Compound 4, half-maximal inhibitory concentration: 55900 nM
Compound 4: the middle estimate sits 1.8-fold (0.25 log units) above what was measured, and the stated range covers the measured number.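

Putting chloro in place of fluoro on the core of compound 2 gives a 1.4-fold higher number from compound 2 to compound 4 (0.15 log units; within the scatter), so in this assay this core shows no clear effect of the change. Set beside the step on the core of compound 1, this neither shows that the change carries over from one core to the other with the same size nor shows that its size depends on the core: the same change on two cores in this assay, an at least 2.9-fold higher number (0.46 log units; beyond the scatter) from compound 1 to compound 3 and a 1.4-fold higher number (0.15 log units; within the scatter) from compound 2 to compound 4; the limit leaves it open whether they differ. A true number for compound 3 is what is missing, as its reading is a limit of the assay and not a number: the limit of > 100000 nM in this assay, at which 1 of the 4 values shown sits.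

The compounds shown leave open what happens when the halogen on the aromatic ring gives way to another group, such as a methyl, a methoxy or an amine. They also leave open whether the primary sulfonamide can be replaced, for example by a carboxylic acid, and whether the same change would behave alike on a third core.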